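The compounds below may be only part of what the source reports. "The series", "measured", "known", "first", "only" and "open" are said of these compounds alone.

Compound 1 `CCCOC(=O)c1[nH]c(C(=O)OC)c(C(=O)OC(C)(C)C)c1C` gives 3200 nM.
Compound 2 `CCN1CCC(OC(=O)c2[nH]cc(C(=O)OC(C)C(C)(C)C)c2C)C1` gives 260 nM.
Compound 3 `CCCOC(=O)c1[nH]c(C)c(C(=O)OC(C)C(C)(C)C)c1C` gives 15800 nM.

In an assay on CHO cells for inhibition of metabotropic glutamate receptor 1 (Rattus norvegicus) (on this read-out lower numbers stand for stronger inhibition and higher numbers for weaker inhibition), compound 1 stands second highest of the three numbers shown. Its nearest neighbour is compound 3, whose value in this assay is 15800 nM, a gap beyond the usual scatter; the furthest is compound 2, which in this assay gives 260 nM, a gap also well beyond the scatter. Compound 4 `CCCOC(=O)c1[nH]c(C(=O)Sc2ccccn2)c(C(=O)OC(C)(C)C)c1C` has not been measured in this assay. It differs from compound 1 in one place: (pyridin-2-yl)sulfanyl in place of methoxy on a carbonyl carbon. Among the measured compounds shown here, no pair of measured compounds shows this change, so no step for it is known. The step from compound 1 to compound 4 in this assay is therefore expected to be modest and is estimated as a 1.6-fold lower number from compound 1 to compound 4 (0.20 log units; within the scatter), with a lower number, although it may well fall within the scatter. On this basis compound 4 is expected to give about 2000 nM, in a range from 500 nM to 8000 nM.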

Compound 4, half-maximal inhibitory concentration: 3200 nM
The estimate for compound 4 lay 1.6-fold (0.20 log units) below the measured number; measured number inside the range.
By their numbers in this assay, from the lowest: compound 2; then compounds 1 and 4 (each within the scatter of the next); then compound 3.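

In this assay, putting (pyridin-2-yl)sulfanyl in place of methoxy on this carbonyl carbon gives no change at the digits printed from compound 1 to compound 4 (within the scatter). Among the compounds shown here, this is the first single-place step, as compounds 1, 2 and 3 differ from one another in more than one place, and it shows that this position can take a group of 7 heavy atoms with a six-membered aromatic ring instead of one of 2 heavy atoms and no ring, with no change in the number beyond the scatter. No supporting measurement is available to account for this result.

Going by these compounds, whether a carboxylic acid, a primary amide or a dimethylamino group on this carbonyl carbon would leave the number equally unchanged remains open. So does whether a benzyl group in place of the pyridine ring would read the same.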